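A few compounds are considered here, and "the series" means these few. Any claim that something is new, unique, unknown or untested is made for them only; others in the source may bear on it.

Two analogues of the shared core have been run so far. Compound 1 `COc1cc(C)cc(-c2c(-c3ccnc(-c4ccc(N(C)C)cc4)c3)cnn2CC#N)c1`, in a functional assay on HOP-62 cells (Homo sapiens) for inhibition, read by sulforhodamine B assay, with a stated time of 48 h (on this read-out lower numbers stand for stronger inhibition of growth and higher numbers for weaker inhibition of growth), gives 263 nM. Compound 2 `COc1cc(C)cc(-c2nn(CC#N)cc2-c2ccnc(-c3ccc(N(C)C)cc3)c2)c1`, which carries the same groups arranged differently about the core, gives 390 nM in this assay. For the measured compounds named here, on these two numbers compound 2 stands alongside compound 1 within the usual scatter of repeated runs, so the pair cannot be told apart on the evidence in hand, and no step between measured compounds is available to anchor a trend.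

Compound 3 `Cc1cc(O)cc(-c2nn(CC#N)cc2-c2ccnc(-c3ccc(N(C)C)cc3)c2)c1` is the next member to be measured in this assay. Relative to compound 2 the change is hydrogen in place of methyl on an oxygen on an aromatic ring; cut one bond further out it reads methoxy to hydroxy, or 3-methoxy-5-methylphenyl to 3-hydroxy-5-methylphenyl. Nothing measured in this series speaks to the effect of this exchange, so the expectation rests on the size of the change alone. A step not clearly beyond the scatter is expected, a 1.3-fold higher number from compound 2 to compound 3 (0.11 log units; within the scatter), leaning if anything towards a somewhat higher number. For compound 3 the estimate in this assay is 500 nM, with a range from 200 nM to 1500 nM.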

Compound 3, concentration for 50% growth inhibition: 2820 nM
Beside the measured number, compound 3's estimate is 5.6-fold (0.75 log units) below it; the whole stated range lies below it.
By their numbers in this assay, from the lowest: compounds 1 and 2 (each within the scatter of the next); then compound 3.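

Exchanging methoxy for hydroxy gives the series its first step between compounds that differ in one place: in this assay it is a 7.2-fold higher number from compound 2 to compound 3 (0.86 log units; beyond the scatter). The 3-methoxy-5-methylphenyl group is therefore not indifferent to what sits on its oxygen, and removing a single methyl, one heavy atom, is enough to carry the read-out clearly beyond the scatter towards weaker inhibition of growth. Of the two forms compared at this position on the arrangement of compound 2, the methoxy form gives the lower number, and nothing in hand accounts for the size of the step.

Open, going by these compounds, is whether the same exchange has a comparable effect on the arrangement of compound 1, for which only the methoxy form appears here. Also open, on these data alone, is whether the read-out depends on the methyl as such or on the free hydroxy, a question that an ethoxy group, a longer ether chain or an amine at the same place on the aromatic ring would help to separate.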